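Compound 4: cyclobutyl on the aromatic nitrogen

The compounds below may be only part of what the source reports. "The series", "measured", "known", "first", "only" and "open" are said of these compounds alone.

In a physicochemical assay for solubility, in phosphate buffer, at pH 7.4 (a lower number here means a less soluble compound, a higher number a more soluble compound), compound 3 `CN(C)C(=O)CN1CCC(c2cc3c(-c4ccc(=O)n(CCC5CCOCC5)c4)ccnc3[nH]2)CC1` stands second of three at 370000 nM with compound 1 `CN(C)C(=O)CN1CCC(c2cc3c(-c4ccc(=O)n(C5CCOCC5)c4)ccnc3[nH]2)CC1` higher at 840000 nM and compound 2 `CC(C)n1cc(-c2ccnc3[nH]c(C4CCN(CC(=O)N(C)C)CC4)cc23)ccc1=O` lower at 110000 nM on the same core. Compound 4 `CN(C)C(=O)CN1CCC(c2cc3c(-c4ccc(=O)n(C5CCC5)c4)ccnc3[nH]2)CC1` differs from compound 3 by cyclobutyl in place of 2-(oxan-4-yl)ethyl on an aromatic nitrogen with cyclobutyl in place of 2-(oxan-4-yl)ethyl on an aromatic nitrogen. The closest guide is a 3.4-fold higher number from compound 2 to compound 3 (0.53 log units; beyond the scatter) read in reverse, as isopropyl, like cyclobutyl, is carbon only. Also relevant are a 7.6-fold lower number from compound 1 to compound 2 (0.88 log units; beyond the scatter) and the smaller 2.3-fold lower number from compound 1 to compound 3 (0.36 log units; beyond the scatter) in the same direction. An estimated 3.1-fold lower number from compound 3 to compound 4 (0.49 log units; beyond the scatter) is expected in this assay from these modest steps. For compound 4 the estimate is 120000 nM with 45000 nM to 300000 nM as the expected range.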

Compound 4, solubility: > 1000000 nM
Compound 4: no number, only a limit; the forecaster's own chance of this, stated with the estimate: 5%; middle value at least 8.3-fold (0.92 log units) from the limit.
By their numbers in this assay, from the lowest: compound 2; then compound 3; then compound 1. At a limit, above all of these: compound 4.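

Compound 4 reads > 1000000 nM in this assay, which is a limit and not a number. Carbon-only groups on the aromatic nitrogen now stand at both ends of the series, with an at least 9.0-fold higher number from compound 2 to compound 4 (0.95 log units; beyond the scatter) for cyclobutyl against isopropyl, and cyclobutyl also exceeds the larger 2-(oxan-4-yl)ethyl, with an at least 2.7-fold higher number from compound 3 to compound 4 (0.43 log units; beyond the scatter). Against oxan-4-yl the step is an at least 1.1-fold higher number from compound 1 to compound 4 (0.07 log units; that floor lies within the scatter), so no order of those two can be stated, and every step to compound 4 is only a floor: the limit of > 1000000 nM in this assay, at which 1 of the 4 values shown sits.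

From the compounds shown here alone, the true value for compound 4 stays open. So does the reading of cyclopentyl, or of a chain ending in a carboxylic acid, on this nitrogen.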